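A step from 4-methoxyphenyl to 2,4,6-trimethylphenyl

This account rests on a few compounds, and the source may have more. Where it says the series, first, only, none or still open, it means among the compounds named here.

In a functional assay on MCF7 cells (Homo sapiens) for inhibition, read by MTT assay, with a stated time of 48 h (a lower number here means a stronger inhibitor, a higher number a weaker inhibitor), compound 1 `O=C(CC(c1ccccc1)C(C(=O)Nc1ccccn1)C(=O)Nc1ccccn1)c1ccccc1` is recorded as "not active" (no number reported), with no number given. Compound 2 `COc1ccc(C(CC(=O)c2ccccc2)C(C(=O)Nc2ccccn2)C(=O)Nc2ccccn2)cc1` gives 48300 nM, the only numerical result so far, so it cannot yet be ranked against another measured value. In compound 3 `Cc1cc(C)c(C(CC(=O)c2ccccc2)C(C(=O)Nc2ccccn2)C(=O)Nc2ccccn2)c(C)c1`, 2,4,6-trimethylphenyl takes the place of 4-methoxyphenyl on a saturated chain carbon bound to two saturated chain carbons (2,4,6-trimethylphenyl in place of 4-methoxyphenyl on a saturated chain carbon bound to two saturated chain carbons). For the measured compounds named here, no measured step is available as a guide, and the estimated change a 1.1-fold lower number from compound 2 to compound 3 (0.03 log units; within the scatter) is expected to stay within the usual scatter, with no clear direction. For compound 3, the expected value is 45000 nM, with an estimated range of 15000 nM to 100000 nM.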

Compound 3, half-maximal inhibitory concentration: 28800 nM
Compound 3: middle estimate off by 1.6-fold (0.19 log units), on the high side; the range from low to high includes it.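

In this assay, for the compounds shown here, putting 2,4,6-trimethylphenyl in place of 4-methoxyphenyl gives a 1.7-fold lower number from compound 2 to compound 3 (0.22 log units; within the scatter), the first step that can be read at this position. On a saturated chain carbon bound to two saturated chain carbons, these two groups therefore give values within the scatter of each other, while steps to compound 1 cannot be read. No measurement shown here bears on the reason for this result. From the compounds shown here alone, what an amine or a carboxylic acid would do at this position remains open, as does the effect of any change to the shared core.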